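Phenyl on the Ring Nitrogen of Compound 2

The source may report more compounds than this note shows. Statements on the series, on what has been measured and on what is new or still open speak of the compounds shown alone.

compound 1 `COc1cccc(C2=NNC(c3ccc(Cl)cc3)C2O)c1` — 49 nM
compound 2 `COc1cccc(C2=NNC(c3ccc(Br)cc3)C2O)c1` — 49 nM
compound 3 `COc1cccc(C(=O)C(O)C(Nc2ccc(F)c(Cl)c2)c2ccc(Br)cc2)c1` — 9.9 nM

In a functional assay on MCF7 cells (Homo sapiens) for antiproliferative activity, read by sulforhodamine B assay, with a stated time of 48 h (a lower number here means a stronger inhibitor, a higher number a weaker inhibitor), compound 2 gives 49 nM, level with compound 1 at the digits shown, and together they are the highest of the three numbers. Compound 3 gives 9.9 nM, a lower number on a different, open-chain skeleton. Compound 4 `COc1cccc(C2=NN(c3ccccc3)C(c3ccc(Br)cc3)C2O)c1` differs from compound 2 in one place: phenyl in place of hydrogen on an amine nitrogen in a ring. Among the measured compounds shown here, the only measured step, no change at the digits printed from compound 1 to compound 2 (within the scatter), exchanges one halogen for another on an aromatic carbon and does not touch the ring nitrogen, so no measured step bears directly on this change. For the measured compounds named here, with no precedent in hand, the step of a 1.2-fold lower number from compound 2 to compound 4 (0.09 log units; within the scatter) is expected to lie within the scatter. Compound 4 is therefore estimated at 40 nM, with a range from 12 nM to 130 nM.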

Compound 4, half-maximal inhibitory concentration: 11 nM
The estimate for compound 4 lay 3.6-fold (0.56 log units) above the measured number; measured number below the stated range.
By their numbers in this assay, from the lowest: compounds 3 and 4 (each within the scatter of the next); then compounds 1 and 2 (each within the scatter of the next).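

In this assay the amine nitrogen in the ring, unchanged across the earlier cyclic pair, proves open to substitution: phenyl in place of hydrogen gives a 4.5-fold lower number from compound 2 to compound 4 (0.65 log units; beyond the scatter) and brings a clear gain, which the halogen exchange could not reveal. Nothing available accounts for this gain. The compounds shown leave open whether a methyl, a benzyl or a substituted phenyl on this nitrogen would give a similarly low number. They also leave open whether the same step holds with chloro in place of bromo.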